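Shortening the Dimethylamino Chain: Compound 2 to Compound 3

This account rests on a few compounds, and the source may have more. Where it says the series, first, only, none or still open, it means among the compounds named here.

Among the measured compounds shown here, compound 2 `COc1ccc(-c2nc3cc(-c4nc5cc(CCCN(C)C)ccc5[nH]4)ccc3[nH]2)cc1` holds the highest of the two numbers measured so far: in a functional assay on SK-MEL cells (Homo sapiens) for cytotoxicity (on this read-out lower numbers stand for stronger inhibition and higher numbers for weaker inhibition), compound 2 gives 10000 nM, whereas compound 1 `COc1ccc(-c2nc3cc(-c4nc5cc(N6CCN(C)CC6)ccc5[nH]4)ccc3[nH]2)cc1` gives 1100 nM. For the measured compounds named here, the only measured step, a 9.1-fold higher number from compound 1 to compound 2 (0.96 log units; beyond the scatter), concerns a different exchange on the aromatic carbon and bears only loosely on the present change. Compound 3 `COc1ccc(-c2nc3cc(-c4nc5cc(CN(C)C)ccc5[nH]4)ccc3[nH]2)cc1` differs from compound 2 by dimethylamino in place of 2-(dimethylamino)ethyl on a saturated chain carbon bound to an aromatic carbon. Going by the values given here, no measured pair shows a change in chain length alone, so the step is expected to stay within the scatter, no change at the digits printed from compound 2 to compound 3 (within the scatter). Compound 3 is therefore estimated at 10000 nM, within 3000 nM to 30000 nM.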

Compound 3, half-maximal inhibitory concentration: 10000 nM
For compound 3 middle estimate and measured number coincide at the digits printed; the range from low to high includes it.
By their numbers in this assay, from the lowest: compound 1; then compounds 2 and 3 (each within the scatter of the next).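

In this assay, among the compounds shown here, dimethylamino in place of 2-(dimethylamino)ethyl on a saturated chain carbon bound to an aromatic carbon gives no change at the digits printed from compound 2 to compound 3 (within the scatter), so shortening the chain, which the earlier compounds did not vary, leaves the number unmoved for this pair. The shorter chain also stands as far from 4-methylpiperazin-1-yl as the longer one did, with a 9.1-fold higher number from compound 1 to compound 3 (0.96 log units; beyond the scatter). No measurement shown here accounts for this result. The compounds shown leave open whether morpholine or piperidine on the aromatic carbon would match compound 1, and whether a primary amine in place of dimethylamino would alter the number.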